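The source may hold more compounds than are shown below. What is called first, only, known or untested is meant among the compounds shown, and "the series" means these compounds.

Measured so far:
compound 1, `Cc1ccc(CNC(=O)c2nn(-c3ccc(F)cc3)c(CC[C@@H](O)C[C@@H](O)CC(=O)O)c2C(C)C)cc1`: 800 nM
compound 2, `Cc1ccc(CNC(=O)c2nn(-c3ccc(F)cc3)c(OC[C@@H](O)C[C@@H](O)CC(=O)O)c2C(C)C)cc1`: 2110 nM

Within the data shown here, in a functional assay on L6 cells (Rattus norvegicus) for inhibition (on this read-out higher numbers stand for weaker inhibition and lower numbers for stronger inhibition), compound 2 gives 2110 nM, the highest of the two numbers at hand; the nearest is compound 1, and the single measured step, a 2.6-fold higher number from compound 1 to compound 2 (0.42 log units; beyond the scatter), concerns the chain on the aromatic carbon of the shared core and nothing else.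

Compound 3, `CC(C)c1c(C(=O)NCc2ccccc2Cl)nn(-c2ccc(F)cc2)c1OC[C@@H](O)C[C@@H](O)CC(=O)O`, is the next one to be measured in this assay. It differs from compound 2 in one place only: 2-chlorophenyl in place of 4-methylphenyl on a saturated chain carbon bound to an amide-type nitrogen. Read one bond further out, (4-methylbenzyl)carbamoyl becomes (2-chlorobenzyl)carbamoyl; the chain on the aromatic carbon stays as in compound 2.

Among the measured compounds shown here, no measured step bears on this part of the core. For the measured compounds named here, the one step available, a 2.6-fold higher number from compound 1 to compound 2 (0.42 log units; beyond the scatter), exchanges the chain and says nothing about the aryl on the saturated chain carbon. Going by the values given here, with no precedent, no step beyond the usual scatter is expected in either direction, and the range is kept wide.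

Compound 3 is therefore expected to give 2000 nM in this assay, between 700 nM and 6000 nM. The expected step that this estimate means is a 1.1-fold lower number from compound 2 to compound 3 (0.02 log units; within the scatter).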

Compound 3, half-maximal inhibitory concentration: 8450 nM
Compound 3: middle estimate off by 4.2-fold (0.63 log units), on the low side; measured number above the stated range.
By their numbers in this assay, from the lowest: compound 1; then compound 2; then compound 3.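

In this assay, the aryl on the saturated chain carbon bound to an amide-type nitrogen proves sensitive: exchanging 4-methylphenyl for 2-chlorophenyl gives a 4.0-fold higher number from compound 2 to compound 3 (0.60 log units; beyond the scatter), a weakening beyond the scatter, although the heavy-atom count of the group stays the same. The earlier step concerned only the chain on the aromatic carbon, so this result adds a second site in the series where a single change moves the number beyond the scatter. This exchange alters both the substituent and its place on the ring, and no available data explain the loss of inhibition or separate those two changes.

Still open, going by these compounds, is how 4-chlorophenyl, 2-methylphenyl or unsubstituted phenyl on the same carbon would compare, which would show whether the step follows the chlorine, its place on the ring or the loss of the methyl group. Also open, on these data alone, is whether 2-chlorophenyl would give a comparable step alongside the 6-carboxy-3,5-dihydroxyhexyl chain of compound 1, since the step is read only on the chain of compound 2.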